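A few compounds are considered here, and "the series" means these few. Any claim that something is new, unique, unknown or untested is made for them only; others in the source may bear on it.

Measured so far in a functional assay for agonist activity at G protein-coupled receptor 88 (Homo sapiens), read by HTRF and cAMP accumulation; on this read-out higher numbers stand for an effect only at larger amounts of compound and lower numbers for an effect already at smaller amounts:
- compound 1 `CC[C@H](C)[C@H](N)CN(C(=O)[C@@H]1C[C@H]1c1ccccc1)c1ccc(-c2ccc(COC)cc2)cc1`: 35 nM
- compound 2 `CC[C@H](C)[C@H](N)CN(C(=O)[C@H]1C[C@@H]1c1ccccn1)c1ccc(-c2ccc(COC)cc2)cc1`: 1200 nM

Compound 2 gives the highest number of the two in this assay; its nearest neighbour is compound 1, and the step of a 34-fold higher number from compound 1 to compound 2 (1.54 log units; beyond the scatter) is beyond the scatter. That step exchanges 2-phenylcyclopropyl for 2-(pyridin-2-yl)cyclopropyl on the carbonyl carbon and at the same time changes the drawn configuration of the cyclopropane ring.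

Compound 3 `CC[C@H](C)[C@H](N)CN(C(=O)[C@@H]1C[C@H]1c1ccccn1)c1ccc(-c2ccc(COC)cc2)cc1` is not yet measured. Relative to compound 2, (the two compounds have the same atoms and bonds and differ only in configuration as drawn: 2 of 4 stereo elements differ; a stereocentre at a saturated ring carbon is drawn S in compound 2 and R in compound 3; a stereocentre at a saturated ring carbon is drawn S in compound 2 and R in compound 3). The ring is thus drawn in the configuration seen in compound 1. Among the compounds with values here, no measured step separates configuration from the aromatic exchange. Within the data shown here, the size of a 34-fold higher number from compound 1 to compound 2 (1.54 log units; beyond the scatter) is the only guide, and that step carries both changes at once.

For compound 3 a lower number than for compound 2 is expected, a 10-fold lower number from compound 2 to compound 3 (1.00 log units; beyond the scatter), estimated at 120 nM within 25 nM to 700 nM.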

Compound 3, half-maximal effective concentration: 15 nM
Compound 3: middle estimate off by 8.0-fold (0.90 log units), on the high side; measured number outside the range, below it.
By their numbers in this assay, from the lowest: compound 3; then compound 1; then compound 2.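

In this assay, within the data shown here, the drawn configuration of the cyclopropane ring alone accounts for an 80-fold lower number from compound 2 to compound 3 (1.90 log units; beyond the scatter), the largest step so far. The high number of compound 2 therefore traces to the ring configuration rather than to the aromatic exchange, because of this: the fact that compounds 2 and 3 differ only in the configuration as drawn

With the configuration held as in compound 1, pyridin-2-yl in place of phenyl gives a 2.3-fold lower number from compound 1 to compound 3 (0.37 log units; beyond the scatter), a modest step, so the aromatic exchange that appeared damaging in the earlier pair does not raise the number at this position.

Open, as far as these compounds go, is whether pyridin-3-yl, pyridin-4-yl or a thiophene ring on the same saturated ring carbon would follow pyridin-2-yl. Also open, from the compounds shown here alone, is whether the phenyl series shows an equally large dependence on ring configuration.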